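The source may report more compounds than this note shows. Statements on the series, on what has been measured and on what is new or still open speak of the compounds shown alone.

Working notes on the series, all read in a functional assay on HL-60 cells (Homo sapiens) for inhibition, read by MTT assay, with a stated time of 48 h, tested at 10 uM; on this read-out lower numbers stand for less inhibition of growth and higher numbers for more inhibition of growth at the one concentration tested. Compound 1 `Cc1cc(=O)c2c(O)c(CN3CCC(Cc4ccccc4)CC3)c(O)c([C@H]3CCN(C)C[C@H]3O)c2o1` gives 28%. Compound 2 `Cc1cc(=O)c2c(O)c(CN3CCC(c4ccccc4)CC3)c(O)c([C@H]3CCN(C)C[C@H]3O)c2o1` gives 26%. Compound 3 `Cc1cc(=O)c2c(O)c(CN(C(C)C)C(C)C)c(O)c([C@H]3CCN(C)C[C@H]3O)c2o1` gives 21%, within the scatter of both other numbers, so it stands apart from neither.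

Compound 4 `Cc1cc(=O)c2c(O)c(CN3CCCCC3)c(O)c([C@H]3CCN(C)C[C@H]3O)c2o1` is not yet measured. The change from compound 3 is piperidin-1-yl in place of diisopropylamino on a saturated chain carbon bound to an aromatic carbon; in words, piperidin-1-yl in place of diisopropylamino on a saturated chain carbon bound to an aromatic carbon.

Going by the values given here, no measured step makes this exchange. Among the compounds with values here, the only one available is a number 2 percentage points lower from compound 1 to compound 2 (within the scatter), a change of phenyl in place of benzyl on a saturated ring carbon, and it bears only indirectly. The gaps from compound 3 to compound 1 and compound 2, which both carry a substituted piperidin-1-yl, also stay within the scatter. With compound 3 at 21%, no change beyond the scatter is expected in this assay. The estimated step is a number 2 percentage points higher from compound 3 to compound 4 (within the scatter). For compound 4 the expected value is 23%, with an estimated range of 11% to 35%.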

Compound 4, percent growth inhibition at one concentration: 32%
Beside the measured number, compound 4's estimate is 9 percentage points below it; low and high end bracket the measured number.
By their numbers in this assay, from the lowest: compounds 3, 2, 1 and 4 (each within the scatter of the next, the first and the last beyond it).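

Going by these compounds alone, the exchange of piperidin-1-yl for diisopropylamino on a saturated chain carbon bound to an aromatic carbon is the first change to give a step beyond the scatter in this assay: a number 11 percentage points higher from compound 3 to compound 4 (beyond the scatter). Substituents on a saturated ring carbon of the piperidin-1-yl group do not separate from the unsubstituted group, with hydrogen in place of phenyl giving a number 6 percentage points higher from compound 2 to compound 4 (within the scatter) and hydrogen in place of benzyl giving a number 4 percentage points higher from compound 1 to compound 4 (within the scatter). Nothing available accounts for the step from diisopropylamino to piperidin-1-yl.

Open, going by these compounds, is whether a pyrrolidin-1-yl or morpholin-4-yl group at the same place would read with compound 3 or with compound 4. Also open, on these data alone, is whether a hydroxyl or a carboxylic acid on that saturated ring carbon would shift the number beyond the scatter.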